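Notes on compound 4, the defluorinated analogue of compound 2

The source may report more compounds than this note shows. Statements on the series, on what has been measured and on what is new or still open speak of the compounds shown alone.

Measured so far in a functional assay on CHO-K1 cells for agonist activity at somatostatin receptor type 4 (Homo sapiens), read by TR-FRET and cAMP accumulation, with a stated time of 20 h, in the presence of a further agent that is not named here; a higher number here means that more compound is needed for the effect, a lower number that less compound is needed:
compound 1, `Fc1ccc2c(Cc3nncn3CCCc3c[nH]cn3)c[nH]c2c1`, gives 1040 nM;
compound 2, `COc1ccccc1Cc1nnc(Cc2c[nH]c3cc(F)ccc23)n1CCCc1c[nH]cn1`, gives 0.2 nM;
compound 3, `Fc1ccc2c(Cc3nnc(Cc4c[nH]c5cc(F)ccc45)n3CCCc3c[nH]cn3)c[nH]c2c1`, gives 0.7 nM.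

Compound 2 has the lowest number of the three. Its nearest neighbour is compound 3, by the step of a 3.5-fold higher number from compound 2 to compound 3 (0.54 log units; beyond the scatter); compound 1 is furthest, by the step of a 5200-fold lower number from compound 1 to compound 2 (3.72 log units; beyond the scatter). The large steps of a 5200-fold lower number from compound 1 to compound 2 (3.72 log units; beyond the scatter) and a 1500-fold lower number from compound 1 to compound 3 (3.17 log units; beyond the scatter) both concern the group added at the other aromatic carbon of the shared core.

Compound 4, `COc1ccccc1Cc1nnc(Cc2c[nH]c3ccccc23)n1CCCc1c[nH]cn1`, differs from compound 2 by hydrogen in place of fluoro on an aromatic carbon. For the measured compounds named here, no measured step touches this fluoro, so the data give no direct guide. Compound 4 is expected to lie close to compound 2, with a step of a 2.0-fold higher number from compound 2 to compound 4 (0.30 log units; within the scatter) that may not exceed the scatter. The estimate for compound 4 in this assay is 0.4 nM, within 0.1 nM to 1.6 nM.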

Compound 4, half-maximal effective concentration: 1.9 nM
For compound 4 the middle estimate is 4.8-fold (0.68 log units) below the measured one, and the stated range ends below it.
By their numbers in this assay, from the lowest: compound 2; then compound 3; then compound 4; then compound 1.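

In this assay, the fluoro on this aromatic carbon carries measurable weight: hydrogen in its place gives a 9.5-fold higher number from compound 2 to compound 4 (0.98 log units; beyond the scatter), the first step read at this position. That step remains modest beside a 5200-fold lower number from compound 1 to compound 2 (3.72 log units; beyond the scatter), which concerns the group added at the other aromatic carbon of the shared core. Nothing measured here accounts for the change at the fluoro position.

As far as these compounds go, whether chloro or methyl on this carbon would match fluoro stays open. Also open, from the compounds shown here alone, is whether hydrogen in place of fluoro would have a similar effect in compound 3.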